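A few compounds are considered here, and "the series" means these few. Any claim that something is new, unique, unknown or untested is made for them only; others in the source may bear on it.

Compound 1 `OC[C@H]1O[C@@H](n2cnc3c(CSc4cccc(Br)c4)ncnc32)[C@H](O)[C@@H]1O` gives 363 nM in an assay on isolated protein for binding affinity to Equilibrative nucleoside transporter 1 (Homo sapiens); on this read-out higher numbers stand for weaker inhibition and lower numbers for stronger inhibition.
Compound 2 `OC[C@H]1O[C@@H](n2cnc3c(CSc4ccc(F)cc4)ncnc32)[C@H](O)[C@@H]1O` gives 158 nM.

Among the measured compounds shown here, compound 2 holds the lowest of the two numbers, and the single measured step, a 2.3-fold lower number from compound 1 to compound 2 (0.36 log units; beyond the scatter), separates it from its only neighbour. Compound 3 `COc1ccc(SCc2ncnc3c2ncn3[C@@H]2O[C@H](CO)[C@@H](O)[C@H]2O)cc1` differs from compound 2 by methoxy in place of fluoro on an aromatic carbon. The measured step concerns another exchange on that ring and bears only loosely on this one, so no strong shift is expected; the step is estimated as a 1.0-fold higher number from compound 2 to compound 3 (0.01 log units; within the scatter). Compound 3 is estimated at 160 nM, with a range from 60 nM to 420 nM.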

Compound 3, half-maximal inhibitory concentration: 617 nM
The estimate for compound 3 lay 3.9-fold (0.59 log units) below the measured number; the whole stated range lies below it.
By their numbers in this assay, from the lowest: compound 2; then compounds 1 and 3 (each within the scatter of the next).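

On the aromatic carbon para to a large group, the exchange of fluoro for methoxy is not a neutral one: it gives a 3.9-fold higher number from compound 2 to compound 3 (0.59 log units; beyond the scatter). The 4-methoxyphenyl group thus loses the advantage seen with 4-fluorophenyl, and the comparison with the 3-bromophenyl group shows no separation, with a 1.7-fold higher number from compound 1 to compound 3 (0.23 log units; within the scatter). Nothing at hand explains this shift.

The compounds shown leave open how an amine or a longer chain such as ethoxy would behave at this position. They also leave open whether hydrogen there would sit nearer to fluoro or to methoxy.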